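The source may report more compounds than this note shows. Statements on the series, on what has been measured and on what is new or still open speak of the compounds shown alone.

Working notes on the series: in a functional assay on HepG2 cells (Homo sapiens) for inhibition, read by MTT assay, with a stated time of 48 h (on this read-out lower numbers stand for stronger inhibition and higher numbers for weaker inhibition), compound 1 `c1ccc(-c2ccnc3c2c(-c2ccccc2)nn3-c2ccccc2)cc1` gives 3210 nM and compound 2 `O=C(C=CNc1cc(-c2ccccc2)nn1-c1ccccc1)c1ccc(Br)cc1` gives 8810 nM, while compound 3 `CN1CCN(c2ccc(-c3c(C#N)c(-c4ccc(Cl)cc4)nc4c3c(-c3ccccc3)nn4-c3ccccc3)cc2)CC1` gives 14600 nM on the same read-out. Compound 2 lies within the scatter of compound 3 and beyond the scatter of compound 1, whose number is lower. The difference hydrogen in place of bromo on an aromatic carbon leads from compound 2 to compound 4 `O=C(C=CNc1cc(-c2ccccc2)nn1-c1ccccc1)c1ccccc1` and puts hydrogen in place of bromo on an aromatic carbon, para to a large group. For the measured compounds named here, no measured pair shows this change, so the expectation rests on compound 2 alone. In this assay the estimated step of a 1.1-fold higher number from compound 2 to compound 4 (0.06 log units; within the scatter) is expected to stay within the scatter. Compound 4 is estimated at 10000 nM with an expected range from 4000 nM to 28000 nM on this read-out.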

Compound 4, half-maximal inhibitory concentration: 2660 nM
The estimate for compound 4 lay 3.8-fold (0.58 log units) above the measured number; measured number below the stated range.
By their numbers in this assay, from the lowest: compounds 4 and 1 (each within the scatter of the next); then compounds 2 and 3 (each within the scatter of the next).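

In this assay, for the compounds shown here, hydrogen in place of bromo on the aromatic carbon para to a large group gives a 3.3-fold lower number from compound 2 to compound 4 (0.52 log units; beyond the scatter) and is the first single-place change. This position is therefore not indifferent to its substituent, and benzoyl carries the lower number here than (4-bromophenyl)carbonyl. No measurement at hand explains this step.

This single pair leaves open whether other groups at this place, such as methoxy, an amine or a carboxylic acid, would fall nearer compound 2 or compound 4. It also leaves open whether the step would recur on another core.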